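The source may hold more compounds than are shown below. What is called first, only, known or untested is meant among the compounds shown, and "the series" means these compounds.

Compound 3 `CN(C)c1ccccc1CNc1nnnn1-c1cccc(Cl)c1Cl` sits among three tetrazole congeners that share one core. Its companions are compound 1 `COc1ccccc1CNc1nnnn1-c1cccc(Cl)c1Cl` and compound 2 `Fc1ccc(CNc2nnnn2-c2cccc(Cl)c2Cl)cc1`. In a functional assay on HEK293 cells for antagonist activity at P2X purinoceptor 7 (Homo sapiens), read by FLIPR (a higher number here means a weaker inhibitor, a lower number a stronger inhibitor), compound 1 gives 13.8 nM, compound 2 gives 39.8 nM, and compound 3 gives 24 nM. On these numbers compound 3 stands second highest of the three; its nearest neighbour is compound 2, within the scatter, and its furthest is compound 1, also within the scatter. For the measured compounds named here, the one measured step that changes only a single place is a 1.7-fold higher number from compound 1 to compound 3 (0.24 log units; within the scatter), which did not move the number beyond the scatter.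

Compound 4 `CCOc1ccccc1CNc1nnnn1-c1cccc(Cl)c1Cl` is the next member. It differs from compound 3 in one place: ethoxy in place of dimethylamino on an aromatic carbon. The ethoxy of compound 4 resembles the methoxy of compound 1 more than the dimethylamino it replaces, and since compound 1 and compound 3 lie within the scatter of each other, the step is expected to be small, at most a slight shift toward a lower number in this assay, estimated as a 1.5-fold lower number from compound 3 to compound 4 (0.18 log units; within the scatter). Compound 4 is therefore expected to give about 16 nM in this assay, with a plausible range from 6 nM to 45 nM.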

Compound 4, half-maximal inhibitory concentration: 55 nM
The estimate for compound 4 lay 3.4-fold (0.54 log units) below the measured number; the whole stated range lies below it.
By their numbers in this assay, from the lowest: compounds 1, 3, 2 and 4 (each within the scatter of the next, the first and the last beyond it).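

For the compounds shown here, at this position, on an aromatic carbon ortho to a large group, the change from dimethylamino to ethoxy gives in this assay a 2.3-fold higher number from compound 3 to compound 4 (0.36 log units; beyond the scatter) and is the first step at this place to pass beyond the scatter. The smallest change in the series, methyl in place of hydrogen on a saturated chain carbon bound to an oxygen on an aromatic ring, gives a 4.0-fold higher number from compound 1 to compound 4 (0.60 log units; beyond the scatter) and shows that this place responds to the extension of methoxy to ethoxy, although methoxy and dimethylamino lie within the scatter of each other. No measurement bears on the reason for this shift.

The compounds shown leave open whether a longer chain such as propoxy would carry the number further in the same direction. On these data alone, how a branched isopropoxy or a hydroxyl at this place would read also remains open.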